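The compounds below may be only part of what the source reports. "The series", "measured", "known", "first", "only" and "open" are said of these compounds alone.

Working notes on the series

Three compounds of the set have numbers in a functional assay on HepG2 cells (Homo sapiens) for inhibition, with a stated time of 72 h; on this read-out lower numbers stand for stronger inhibition and higher numbers for weaker inhibition. Compound 1 `Cc1cc(Cl)ccc1NC(=O)Nc1nc(Nc2ccccc2)cc(Sc2c[nH]c3ccccc23)n1` gives 8370 nM. Compound 2 `O=C(Nc1ccccc1)Nc1nc(Nc2ccc(Cl)cc2)cc(Sc2c[nH]c3ccccc23)n1` gives 12600 nM. Compound 3 `O=C(Nc1ccccc1)Nc1nc(Sc2c[nH]c3ccccc23)cc(N2CCN(c3ccccn3)CC2)n1` gives 8930 nM, which places it second highest of the three numbers, with compound 1 nearest and compound 2 furthest, both gaps being within the scatter of repeated measurements. Going by the values given here, the one single-place step measured so far is a 1.4-fold lower number from compound 2 to compound 3 (0.15 log units; within the scatter), and that step also stays within the scatter.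

Compound 4 `Cc1cc(Cl)ccc1NC(=O)Nc1nc(Sc2c[nH]c3ccccc23)cc(N2CCN(c3ccccn3)CC2)n1` is not yet measured. It differs from compound 3 by 4-chloro-2-methylphenyl in place of phenyl on an amide-type nitrogen. Among the compounds with values here, no measured pair differs in exactly this place, so nothing bears directly on the step; compounds 1 and 2 carry the two aryl groups in question but also differ elsewhere, and their numbers lie close to each other. Within the data shown here, the only measured step in this assay was within the scatter, so no shift beyond the scatter is expected here either; the step from compound 3 to compound 4 is estimated at a 1.1-fold lower number from compound 3 to compound 4 (0.05 log units; within the scatter). For compound 4 the expected value in this assay is 8000 nM, within an estimated range of 3000 nM to 22000 nM.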

Compound 4, half-maximal inhibitory concentration: 7640 nM
Estimate against measurement, compound 4: 1.0-fold (0.02 log units) above, within the range that was stated.
By their numbers in this assay, from the lowest: compounds 4, 1, 3 and 2 (each within the scatter of the next).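

In this assay, the place on the amide-type nitrogen now has a direct pair: 4-chloro-2-methylphenyl in place of phenyl gives a 1.2-fold lower number from compound 3 to compound 4 (0.07 log units; within the scatter), so this change leaves the number within the scatter. The aromatic carbon gets a second single-place reading, with 4-(pyridin-2-yl)piperazin-1-yl in place of anilino giving a 1.1-fold lower number from compound 1 to compound 4 (0.04 log units; within the scatter), again within the scatter and now with 4-chloro-2-methylphenyl on the amide-type nitrogen. Going by these compounds alone, no supporting data bear on these results, and all steps so far are small.

From the compounds shown here alone, only phenyl and 4-chloro-2-methylphenyl have been seen on the amide-type nitrogen, so it remains open whether any group there moves the number beyond the scatter. An aliphatic chain in place of the aryl group, or a carboxylic acid or an amine on the aryl ring, would test this.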